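Styryl in place of chlorophenyl on the pyrazoline core

The compounds below may be only part of what the source reports. "The series", "measured", "known", "first", "only" and "open" are said of these compounds alone.

Measured compounds:
Compound 1, `Cc1cc(O)c(C2=NN(c3ccc(S(N)(=O)=O)cc3)C(c3ccccc3O)C2)cc1Cl`, gives 46900 nM in a functional assay on A498 cells (Homo sapiens) for antiproliferative activity, with a stated time of 48 h; a lower number here means that less compound is tolerated, a higher number that more compound is tolerated.
Compound 2, `Cc1cc(O)c(C2=NN(c3ccc(S(N)(=O)=O)cc3)C(c3ccccc3Cl)C2)cc1Cl`, gives 61400 nM in this assay.

Compound 2 stands at the highest of the two numbers, yet its separation from compound 1 is small: the step of a 1.3-fold higher number from compound 1 to compound 2 (0.12 log units; within the scatter) lies within the scatter, so the two values cannot be ordered with confidence.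

Compound 3, `Cc1cc(O)c(C2=NN(c3ccc(S(N)(=O)=O)cc3)C(/C=C/c3ccccc3)C2)cc1Cl`, has not yet been measured. It differs from compound 2 by 2-phenylethenyl in place of 2-chlorophenyl on a saturated ring carbon. The only measured step swaps one substituent for another on that same saturated ring carbon, and it stayed within the scatter; no step replaces an aromatic ring there with a 2-phenylethenyl group, so nothing shown bears directly on this change. For the measured compounds named here, with the sole neighbouring step being flat, no shift beyond the scatter is expected in this assay, in either direction.

Compound 3 is therefore estimated at 50000 nM, with a range from 15000 nM to 160000 nM, which corresponds to an expected step of a 1.2-fold lower number from compound 2 to compound 3 (0.09 log units; within the scatter).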

Compound 3, concentration lethal to 50% of the cells: > 100000 nM
Compound 3: no number, only a limit; the forecaster's own chance of this, stated with the estimate: 25%; middle value at least 2.0-fold (0.30 log units) from the limit.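

Compound 3 gives no number in this assay, only a limit of the assay: the limit of > 100000 nM in this assay, at which 1 of the 3 values shown sits.

Even read as a floor, the change on the saturated ring carbon reaches beyond the scatter against the hydroxy-bearing compound, with an at least 2.1-fold higher number from compound 1 to compound 3 (0.32 log units; beyond the scatter), while against the chloro-bearing compound the floor stays within the scatter, with an at least 1.6-fold higher number from compound 2 to compound 3 (0.21 log units; that floor lies within the scatter). The position had looked flat while only the substituent on its aromatic ring was exchanged, and this result shows that 2-phenylethenyl on that carbon can raise the number by more than the scatter in at least one comparison.

From the compounds shown here alone, the true value of compound 3 stays unknown, so the full size of both steps remains open, and these compounds do not show whether the result depends on the double bond outside aromatic rings or on the greater length of the group. Going by these compounds, whether a saturated 2-phenylethyl chain, a benzyl group or an amine on the same carbon would give a number like that of compound 2 or a limit like that of compound 3 also remains open.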